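Methoxybenzyl placement within the biphenyl carboxylic acid series

The source may report more compounds than this note shows. Statements on the series, on what has been measured and on what is new or still open speak of the compounds shown alone.

Compound 3 `COc1ccccc1Cc1cnc(CCc2ccc(-c3ccccc3C(=O)O)cc2)[nH]1` gives 1720 nM in an in vitro functional assay on cells for agonist activity at Bombesin receptor subtype-3 (Homo sapiens), read by luminescence and calcium flux; on this read-out lower numbers stand for an effect already at smaller amounts and higher numbers for an effect only at larger amounts of compound. Going by the values given here, on the three numbers so far it stands second highest. Compound 1 `O=C(O)c1ccccc1-c1ccc(CCc2ncc(-c3ccccc3)[nH]2)cc1` gives 4950 nM, and the step of a 2.9-fold lower number from compound 1 to compound 3 (0.46 log units; beyond the scatter) is modest. Compound 2 `CC(C)(C)CCc1cnc(CCc2ccc(-c3ccccc3C(=O)O)cc2)[nH]1` gives 39 nM, and the step of a 44-fold higher number from compound 2 to compound 3 (1.64 log units; beyond the scatter) is large, as is a 130-fold lower number from compound 1 to compound 2 (2.10 log units; beyond the scatter). Compound 4 `COc1ccc(Cc2cnc(CCc3ccc(-c4ccccc4C(=O)O)cc3)[nH]2)cc1` differs from compound 3 by 4-methoxyphenyl in place of 2-methoxyphenyl on a saturated chain carbon bound to an aromatic carbon. Among the compounds with values here, no measured step compares a 2-methoxyphenyl with a 4-methoxyphenyl at this place: the steps that touch the saturated chain carbon bound to an aromatic carbon exchange the whole group, phenyl for 3,3-dimethylbutyl or for 2-methoxybenzyl, and none of them tells how the two methoxybenzyl arrangements relate. The two compounds have the same atoms, joined differently, and the large swings seen so far all came with a change of group rather than of arrangement. Within the data shown here, with no comparable step in hand, the expectation is a change not beyond the scatter, with wide uncertainty in either direction. Compound 4 is therefore expected to give roughly 1500 nM, within 400 nM to 6000 nM. The step this estimate implies is a 1.1-fold lower number from compound 3 to compound 4 (0.06 log units; within the scatter), expected to fall inside the usual scatter.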

Compound 4, half-maximal effective concentration: 5360 nM
The estimate for compound 4 lay 3.6-fold (0.55 log units) below the measured number, and the stated range covers the measured number.
By their numbers in this assay, from the lowest: compound 2; then compound 3; then compounds 1 and 4 (each within the scatter of the next).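

Changing only the arrangement, with the same atoms in both compounds, gives a 3.1-fold higher number from compound 3 to compound 4 (0.49 log units; beyond the scatter), so at this saturated chain carbon bound to an aromatic carbon the placement of the methoxy group alone shifts the number in this assay. The 4-methoxybenzyl group leaves the number close to that of the phenyl group, with a 1.1-fold higher number from compound 1 to compound 4 (0.03 log units; within the scatter), whereas a 140-fold higher number from compound 2 to compound 4 (2.14 log units; beyond the scatter) shows that both methoxybenzyl compounds remain well apart from the 3,3-dimethylbutyl compound. No available measurement bears on why the two arrangements differ.

Still open, as far as these compounds go, is how an unsubstituted benzyl group would compare with the two methoxybenzyl groups, and whether a hydroxyl group or an amine in place of the methoxy group would keep the same dependence on arrangement. Also open, from the compounds shown here alone, is whether a longer alkyl chain would hold the low number of compound 2 at 39 nM.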